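The compounds below may be only part of what the source reports. "The series", "measured", "known", "first", "only" and "open" are said of these compounds alone.

The story here runs through an ADME assay on CCRF-HSB-2 cells (Homo sapiens) for cytotoxicity, with a stated time of 7 days; a higher number here means that more compound is tolerated, a lower number that less compound is tolerated. Compound 1 `Nc1nc(OCc2ccccc2)c2ncn(/C=C3/CC3(CO)CO)c2n1` gives a value that is a limit of the assay rather than a number, > 20000 nM. Compound 2 `CC(C)Nc1nc(N)nc2c1ncn2/C=C1/CC1(CO)CO` likewise gives only a limit, > 20000 nM. Compound 3 `CC(C)Sc1nc(N)nc2c1ncn2/C=C1/CC1(CO)CO` gives an actual number, 94000 nM. None of the three steps between these compounds can be read because the limit of > 20000 nM in this assay, at which 2 of the 3 values shown sit: the step that the two limits leave unreadable from compound 1 to compound 2, the step that the limit leaves unreadable from compound 1 to compound 3 and the step that the limit leaves unreadable from compound 2 to compound 3 all remain without a size. Compound 2 therefore stands at the limit of the assay, without a number of its own.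

Compound 4 `CCCCNc1nc(N)nc2c1ncn2/C=C1/CC1(CO)CO` differs from compound 2 in a single place: butyl in place of isopropyl on a nitrogen on an aromatic ring. For the measured compounds named here, no measured step bears readably on this change, so the measured compounds give no direction to expect. Compound 4 is expected to give 40000 nM, with a range from 15000 nM to 120000 nM, and may well return only a limit again. The step this estimate means, a step that the limit leaves unreadable from compound 2 to compound 4, is expected to stay within the scatter.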

Compound 4, half-maximal cytotoxic concentration: > 20000 nM
Compound 4: a limit, no number (the forecaster's own chance of this, stated with the estimate: 60%); the middle value lies beyond the limit too.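

Compound 4 gives only a limit of the assay, > 20000 nM, so no step linking it to compound 1, compound 2 or compound 3 can be read: the limit of > 20000 nM in this assay, at which 3 of the 4 values shown sit.

From the compounds shown here alone, whether butyl and isopropyl differ in how much compound the cells tolerate remains open between compound 2 and compound 4.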